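The compounds below may be only part of what the source reports. "The series", "measured", "known", "first", "only" and "open" are said of these compounds alone.

Compound 1 `CC(C)OC(=O)N1CCC(Oc2ncnc3c2CCN3c2ccc(S(C)(=O)=O)cc2F)CC1` is the reference point of this pair. In a functional assay on CHO-K1 cells with Glucose-dependent insulinotropic receptor (Homo sapiens) as the target, read by a luciferase reporter, with a stated time of 5 h (on this read-out higher numbers stand for larger maximal responses and lower numbers for smaller maximal responses), compound 1 gives 91%, the highest of the two numbers available. Among the measured compounds shown here, compound 2 `CC(C)OC(=O)N1CCC(Oc2ncnc3c2CCN3c2ccc(-c3cccn3C)cc2F)CC1` gives 44% in this assay, and the single measured step, a number 47 percentage points lower from compound 1 to compound 2 (beyond the scatter), comes from swapping the group on the aromatic ring, with the carbamate left untouched.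

Compound 3 `CC(C)(C)OC(=O)N1CCC(Oc2ncnc3c2CCN3c2ccc(S(C)(=O)=O)cc2F)CC1` is not yet measured. It differs from compound 1 at the carbamate only: methyl in place of hydrogen on a saturated chain carbon bound to an oxygen next to a carbonyl group and two saturated chain carbons. For the measured compounds named here, no measured step touches this part of the molecule, so the one step available, from compound 1 to compound 2, does not bear on it; it only shows how far the maximal response can move when the aromatic substituent is changed. With nothing comparable for the carbamate, the expectation for compound 3 is a step no larger than the scatter, a number 5 percentage points lower from compound 1 to compound 3 (within the scatter), in no fixed direction. The estimate for compound 3 in this assay is therefore 86%, between 66% and 102%.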

Compound 3, largest response reached (reported as percent of maximum), in percent of the reference or control that the assay uses: 139%
For compound 3 the middle estimate is 53 percentage points below the measured one; measured number above the stated range.
By their numbers in this assay, from the lowest: compound 2; then compound 1; then compound 3.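

Among the compounds shown here, the carbamate end proves as responsive as the aromatic substituent: in this assay the change from isopropyl to tert-butyl gives a number 48 percentage points higher from compound 1 to compound 3 (beyond the scatter) and so moves the read-out upward, whereas the one earlier step, a number 47 percentage points lower from compound 1 to compound 2 (beyond the scatter), went downward. With the methylsulfonyl group and the shared core unchanged, one methyl on the saturated chain carbon bound to the oxygen is enough for a step beyond the scatter. Nothing available explains a step of this size from one methyl.

On these data alone, compound 2 carries only the isopropoxycarbonyl group, so it remains open whether tert-butoxycarbonyl would raise the maximal response with the 1-methyl-1H-pyrrol-2-yl group in place. Also open, as far as these compounds go, is how a cyclobutyl or 1-methylcyclopropyl group would read in place of tert-butyl at this position.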